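A few compounds are considered here, and "the series" means these few. Any claim that something is new, unique, unknown or untested is made for them only; others in the source may bear on it.

In a functional assay on HepG2 cells (Homo sapiens) for cytotoxicity, read by MTT assay, with a stated time of 24 h (a lower number here means a stronger inhibitor, a higher number a weaker inhibitor), compound 1 (`O=C1/C(=C/c2cccnc2)CN(S(=O)(=O)c2ccc(F)cc2)C/C1=C\c1ccccc1F`) gives 15600 nM and compound 2 (`O=C1/C(=C/c2cccnc2)CN(S(=O)(=O)c2ccc([N+](=O)[O-])cc2)C/C1=C\c1ccccc1C(F)(F)F`) gives 9370 nM on the shared core. Among the compounds with values here, these two values lie within the scatter of each other, and they are the only numbers available. The two compounds differ in more than one place, so no single change has yet been measured on its own. Compound 3 (`O=C1/C(=C/c2cccnc2)CN(S(=O)(=O)c2ccc(F)cc2)C/C1=C\c1ccccc1C(F)(F)F`) is reached from compound 2 by one exchange (fluoro in place of nitro on an aromatic carbon), with fluoro in place of nitro on an aromatic carbon, para to a large group. The 4-nitrophenyl thus becomes 4-fluorophenyl. Compound 3 keeps the trifluoromethyl of compound 2 (9370 nM) and takes the (4-fluorophenyl)sulfonyl of compound 1 (15600 nM). With those two values within the scatter of each other, no step beyond the scatter is expected in this assay and no firm direction can be given. The estimated step is a 1.3-fold higher number from compound 2 to compound 3 (0.11 log units; within the scatter) and stays within the scatter. For compound 3 the estimated value is 12000 nM with an expected range from 5500 nM to 25000 nM in this measurement.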

Compound 3, half-maximal inhibitory concentration: 2340 nM
For compound 3 the middle estimate is 5.1-fold (0.71 log units) above the measured one; the whole stated range lies above it.
By their numbers in this assay, from the lowest: compound 3; then compounds 2 and 1 (each within the scatter of the next).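

In this assay, the fluoro in place of nitro exchange on the aromatic carbon para to a large group, with the trifluoromethyl held in place, gives a 4.0-fold lower number from compound 2 to compound 3 (0.60 log units; beyond the scatter), so this position affects the read-out on its own. Trifluoromethyl in place of fluoro on an aromatic carbon, with the (4-fluorophenyl)sulfonyl held in place, gives a 6.7-fold lower number from compound 1 to compound 3 (0.82 log units; beyond the scatter), so the second place matters on its own as well. Both steps are modest and lie beyond the scatter, and they make compound 3 the strongest inhibitor of the three, which the earlier pair, differing in both places at once, could not reveal. No supporting evidence is available to explain either step.

The compounds shown leave open whether the nitro-to-fluoro step would keep its size with fluoro rather than trifluoromethyl on the other aromatic ring. They also do not tell how a chloro, a methoxy or an amine at the same position of the sulfonyl-bearing aromatic ring would compare with the fluoro of compound 3.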